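Aryl Swap on a Bromoacrylamide Core

The source may hold more compounds than are shown below. What is called first, only, known or untested is meant among the compounds shown, and "the series" means these compounds.

compound 1, `C=C(Br)C(=O)Nc1cccc(-c2cn3nc(-c4ccc(OCC)cc4)sc3n2)c1`, 1100 nM
compound 2, `Nc1cccc(-c2cn3nc(-c4ccc(F)cc4)sc3n2)c1`, >= 250000 nM
compound 3, `Nc1cccc(-c2cn3nc(Cc4ccccc4)sc3n2)c1`, 24000 nM

In a functional assay on HeLa cells (Homo sapiens) for inhibition, read by cell counting, with a stated time of 4 days (on this read-out lower numbers stand for stronger inhibition and higher numbers for weaker inhibition), compound 1 gives the lowest of the two numbers shown, and its nearest neighbour, compound 3, sits higher by a margin beyond the scatter. Compound 2 gives only a limit of this assay, (the limit of >= 250000 nM in this assay, at which 1 of the 3 values shown sits). Within the data shown here, the single measured step, an at least 10-fold lower number from compound 2 to compound 3 (1.01 log units; beyond the scatter), concerns the same aromatic carbon of the shared core but exchanges different groups. Compound 4, `C=C(Br)C(=O)Nc1cccc(-c2cn3nc(-c4cccc(OC)c4)sc3n2)c1`, differs from compound 1 by 3-methoxyphenyl in place of 4-ethoxyphenyl on an aromatic carbon. Among the measured compounds shown here, no measured step pairs these two groups, so the writer expects the step of a 1.4-fold higher number from compound 1 to compound 4 (0.13 log units; within the scatter) to stay within the scatter. Compound 4 is therefore estimated at 1500 nM, between 400 nM and 6000 nM.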

Compound 4, half-maximal inhibitory concentration: 1100 nM
Estimate against measurement, compound 4: 1.4-fold (0.13 log units) above; the measured number falls inside the stated range.
By their numbers in this assay, from the lowest: compounds 1 and 4 (each within the scatter of the next); then compound 3. At a limit, above all of these: compound 2.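

Exchanging 4-ethoxyphenyl for 3-methoxyphenyl at this position gives no change at the digits printed from compound 1 to compound 4 (within the scatter) in this assay. Among these compounds, this is the first step at this position measured with the bromoacrylamide present on both sides, and in contrast to an at least 10-fold lower number from compound 2 to compound 3 (1.01 log units; beyond the scatter), which links two compounds with a free amine, it leaves the two aryl groups undistinguished. Nothing at hand explains this result.

No pair shown separates the effect of the bromoacrylamide from that of the free amine. On these data alone, whether a carboxylic acid or a morpholine on this aryl ring would fit equally well remains open.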